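Methylsulfanyl for Methoxy on a Nucleoside Core

This account rests on a few compounds, and the source may have more. Where it says the series, first, only, none or still open, it means among the compounds named here.

Compound 1, `COc1ncnc2c1c(-c1cccs1)cn2[C@@H]1O[C@H](CO)[C@@H](O)[C@H]1O`, gives 70 nM in a functional assay on K562 cells (Homo sapiens), read by MTT assay, with a stated time of 72 h; a lower number here means a stronger inhibitor, a higher number a weaker inhibitor.
Compound 2, `COc1ncnc2c1c(-c1ccco1)cn2[C@@H]1O[C@H](CO)[C@@H](O)[C@H]1O`, gives 60 nM in this assay.
Compound 3, `COc1ncnc2c1c(-c1ccsc1)cn2[C@@H]1O[C@H](CO)[C@@H](O)[C@H]1O`, gives 90 nM in this assay.

Among these three numbers compound 1 stands second highest, yet the steps of a 1.2-fold lower number from compound 1 to compound 2 (0.07 log units; within the scatter) and a 1.3-fold higher number from compound 1 to compound 3 (0.11 log units; within the scatter) both lie within the scatter, so the three cannot be told apart. Compound 4, `CSc1ncnc2c1c(-c1cccs1)cn2[C@@H]1O[C@H](CO)[C@@H](O)[C@H]1O`, differs from compound 1 by methylsulfanyl in place of methoxy on an aromatic carbon. For the measured compounds named here, no measured step touches this group: every step so far swaps the five-membered ring, as in a 1.5-fold higher number from compound 2 to compound 3 (0.18 log units; within the scatter), and every one stays within the scatter. There is thus no direct guide, and the expected step in this assay is no change at the digits printed from compound 1 to compound 4 (within the scatter), none beyond the scatter. Compound 4 is estimated at 70 nM, with a range from 25 nM to 200 nM.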

Compound 4, half-maximal inhibitory concentration: 11600 nM
The estimate for compound 4 lay 170-fold (2.22 log units) below the measured number; measured number above the stated range.
By their numbers in this assay, from the lowest: compounds 2, 1 and 3 (each within the scatter of the next); then compound 4.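

The five-membered ring swaps all stayed within the scatter, but the group on this aromatic carbon, next to the ring nitrogen, matters far more: in this assay, methylsulfanyl in place of methoxy gives a 170-fold higher number from compound 1 to compound 4 (2.22 log units; beyond the scatter), a large loss of strength. The two groups have the same counts of heavy atoms, donors and acceptors, so those counts alone do not foretell the step. Nothing shown gives a reason for it.

On these data alone, whether any replacement of methoxy costs this much remains open; an amine or an ethoxy group here would test that. Also open, as far as these compounds go, is whether the step is the same with furan-2-yl or thiophen-3-yl on the core.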